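Inverting the Hydroxylated Ring Carbon of a Lactone Inhibitor

This account rests on a few compounds, and the source may have more. Where it says the series, first, only, none or still open, it means among the compounds named here.

Measured so far:
compound 1 `O=C1C[C@H](O)C[C@@H](/C=C/c2ccc(Cl)cc2Cl)O1`: 64%; 72% (2 entries)
compound 2 `C[C@]1(O)CC(=O)O[C@H](/C=C/c2ccc(Cl)cc2Cl)C1`: 61%

In an assay for inhibition of 3-hydroxy-3-methylglutaryl-coenzyme A reductase (Rattus norvegicus), tested at 10 ug/mL (on this read-out lower numbers stand for a weaker effect and higher numbers for a stronger effect at the one concentration tested), compound 1 gives 64%; 72% (2 entries), the spread of the several entries of compound 1 in this assay, 64%; 72% (2 entries) showing the repeatability of the read-out. Compound 2 gives 61% in this assay; this is the only number shown for it, and it lies within the scatter of the values of compound 1.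

Compound 3 `C[C@@]1(O)CC(=O)O[C@H](/C=C/c2ccc(Cl)cc2Cl)C1` differs from compound 2 only in configuration: the two compounds have the same atoms and bonds and differ only in configuration as drawn: 1 of 3 stereo elements differ; a stereocentre at a saturated ring carbon is drawn R in compound 2 and S in compound 3. No measured pair among these compounds shows the effect of such an inversion, so the step is expected from the structures alone. In this assay a modest loss is expected for compound 3, a step of a number 16 percentage points lower from compound 2 to compound 3 (beyond the scatter). Compound 3 is estimated at 45%, with a range from 15% to 72%.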

Compound 3, a percentage reported as inhibition, at one concentration (the size of the read-out at that concentration, not a potency): 5%
Estimate against measurement, compound 3: 40 percentage points above, and the stated range ends above it.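

In this assay, inverting the stereocentre at the saturated ring carbon alone gives a number 56 percentage points lower from compound 2 to compound 3 (beyond the scatter), a large step. Configuration at this carbon therefore decides much of the read-out, because no atom or bond changes: the fact that compounds 2 and 3 differ only in the configuration as drawn. The step also far exceeds the spread of repeated results: the several entries of compound 1 in this assay, 64%; 72% (2 entries).

On these data alone, whether the same inversion matters as much without the methyl group on this carbon remains open, as does the outcome with an ethyl group or a longer chain there. Readings at one concentration also give no potency for compound 2 or compound 3.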